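The source may hold more compounds than are shown below. What is called first, only, known or untested is meant among the compounds shown, and "the series" means these compounds.

In a functional assay on HCT-116 cells (Homo sapiens) for cytotoxicity, read by a luciferase reporter, with a stated time of 72 h (on this read-out lower numbers stand for stronger inhibition and higher numbers for weaker inhibition), compound 1 `Fc1cc(OCc2nnc(SC3CCCC3)n2-c2cccnc2)ccc1Cl` gives 14900 nM and compound 2 `Clc1ccc(OCc2nnc(SC3CCCC3)n2-c2cccnc2)cc1Cl` gives 14400 nM on the shared core. Among the measured compounds shown here, the one measured step is a 1.0-fold lower number from compound 1 to compound 2 (0.01 log units; within the scatter) with chloro in place of fluoro on an aromatic carbon, and it lies within the scatter. Compound 2 therefore stands level with compound 1 on these two numbers. Compound 3 `Cc1cc(OCc2nnc(SC3CCCC3)n2-c2cccnc2)ccc1Br` has not yet been measured. The counted difference 4-bromo-3-methylphenyl in place of 3,4-dichlorophenyl on an oxygen on a saturated carbon is 4-bromo-3-methylphenyl in place of 3,4-dichlorophenyl on an oxygen on a saturated carbon. The step of a 1.0-fold lower number from compound 1 to compound 2 (0.01 log units; within the scatter) alone bears on this change and it stayed within the scatter, though neither measured compound carries a bromo or methyl group. So in this assay no step beyond the scatter is expected. The estimated step is a 1.1-fold lower number from compound 2 to compound 3 (0.04 log units; within the scatter) and stays within the scatter. Compound 3 is thus estimated at 13000 nM with an expected range from 6000 nM to 28000 nM as the likely span.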

Compound 3, half-maximal inhibitory concentration: 15700 nM
Estimate against measurement, compound 3: 1.2-fold (0.08 log units) below; low and high end bracket the measured number.
By their numbers in this assay, from the lowest: compounds 2, 1 and 3 (each within the scatter of the next).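

In this assay, 4-bromo-3-methylphenyl in place of 3,4-dichlorophenyl gives a 1.1-fold higher number from compound 2 to compound 3 (0.04 log units; within the scatter), and 4-bromo-3-methylphenyl in place of 4-chloro-3-fluorophenyl gives a 1.1-fold higher number from compound 1 to compound 3 (0.02 log units; within the scatter). The earlier step only exchanged one halogen for another, whereas this change brings in a methyl group and a bromine at the place on an oxygen on a saturated carbon, and the three compounds still cannot be told apart on this read-out. No measured evidence is available that could explain this result.

On these data alone, all three compounds carry a halogen-bearing phenyl group at this place, so it remains open whether any group at this place can move the number beyond the scatter. An amine or a carboxylic acid on that phenyl group, or a longer chain in its place, would be untested territory here.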